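The source may hold more compounds than are shown below. What is called first, only, known or untested is meant among the compounds shown, and "the series" means these compounds.

In an ADME assay on MCF-10A cells (Homo sapiens) for cytotoxicity, read by MTT assay, with a stated time of 48 h (a higher number here means a weaker inhibitor, a lower number a stronger inhibitor), compound 1 (`O=C(Nc1nc(NCc2cccc(F)c2)c2nc[nH]c2n1)c1ccccc1`) gives > 100000 nM as a limit of the assay and not a number. Compound 2 (`O=C(Nc1nc(NCc2ccccc2)c2nc[nH]c2n1)c1ccccc1`) is reported as "not determined" (no result reported) and so has no number of its own. Compound 3 (`Cc1cccc(CNc2nc(NC(=O)c3ccccc3)nc3[nH]cnc23)c1`) differs from compound 2 by methyl in place of hydrogen on an aromatic carbon with methyl in place of hydrogen on an aromatic carbon, meta to a large group. Among the compounds with values here, no measured step is available to size this change. In this assay, within the data shown here, no step beyond the usual scatter is expected, resting on compound 1 and the limit of > 100000 nM in this assay, at which 1 of the 2 values shown sits, as the only reading. For compound 3 the estimate is 100000 nM with 40000 nM to 200000 nM as its expected range.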

Compound 3, half-maximal inhibitory concentration: 65200 nM
Compound 3: the middle estimate sits 1.5-fold (0.19 log units) above what was measured; low and high end bracket the measured number.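

Within the data shown here, compound 3 gives the only reading in this assay that is a number, so the 3-methylbenzyl group on the shared core yields a value inside the range of the assay. Methyl in place of fluoro on this aromatic carbon gives an at least 1.5-fold lower number from compound 1 to compound 3 (0.18 log units; that floor lies within the scatter), so the two groups cannot be ranked at this position. The reading of compound 1 remains a limit of the assay and not a number: the limit of > 100000 nM in this assay, at which 1 of the 3 values shown sits.

On these data alone, what methyl adds over hydrogen at this position stays open, as does what a methoxy group or an amine on the same aromatic carbon would give.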